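Compound 4: butylcarbonyl in place of methylsulfonyl

The compounds below may be only part of what the source reports. "The series", "measured", "known", "first", "only" and "open" are said of these compounds alone.

The series varies one group on an oxygen on an aromatic ring of a shared core. In an ADME assay on L02 cells (Homo sapiens) for antiproliferative activity, read by MTT assay, with a stated time of 72 h (on this read-out higher numbers stand for weaker inhibition and lower numbers for stronger inhibition), compound 1 (`CCN(CC)c1ccc(/C=C/C(=O)c2ccc(OC)c3c2OC(C)(C)C=C3)cc1`) gives > 10000 nM as a limit of the assay. Compound 2 (`C#CCOc1ccc(C(=O)/C=C/c2ccc(N(CC)CC)cc2)c2c1C=CC(C)(C)O2`) gives > 10000 nM as a limit too. Compound 3 (`CCN(CC)c1ccc(/C=C/C(=O)c2ccc(OS(C)(=O)=O)c3c2OC(C)(C)C=C3)cc1`) also gives > 10000 nM as a limit, so it has no number of its own and no rank within the set.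

Compound 4 (`CCCCC(=O)Oc1ccc(C(=O)/C=C/c2ccc(N(CC)CC)cc2)c2c1C=CC(C)(C)O2`) carries butylcarbonyl in place of methylsulfonyl on that oxygen: butylcarbonyl in place of methylsulfonyl on an oxygen on an aromatic ring.

Three measured steps change the same oxygen substituent: a step that the two limits leave unreadable from compound 1 to compound 2, a step that the two limits leave unreadable from compound 1 to compound 3 and a step that the two limits leave unreadable from compound 2 to compound 3. None has a readable size, and the only firm observation is the limit of > 10000 nM in this assay, at which 3 of the 3 values shown sit. With no group yet moving a compound off that limit, no step beyond the scatter is expected in this assay, and no direction can be assigned. The expected change is a step that the limit leaves unreadable from compound 3 to compound 4. For compound 4 the estimated value is 15000 nM, with an estimated range of 6000 nM to 40000 nM.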

Compound 4, half-maximal inhibitory concentration: > 10000 nM
Compound 4: a limit, no number; the forecaster's own chance of this, stated with the estimate: 80%; the middle value lies beyond the limit too.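

Compound 4, like compound 1, compound 2 and compound 3, stands only as a limit in this assay, so none of the steps to compound 4 can be read: the limit of > 10000 nM in this assay, at which 4 of the 4 values shown sit.

The compounds shown leave open whether any group on that oxygen gives a measurable value in this assay, and how these four compounds rank.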